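Pyridin-3-yl in place of cyclohexyloxy: compound 3 to compound 4

The source may report more compounds than this note shows. Statements on the series, on what has been measured and on what is new or still open speak of the compounds shown alone.

Three compounds in this series share the same amide and sulfonamide portion and differ only in the group that sits on the aromatic carbon of the benzylic ring. Compound 1 `CC(C(=O)NCc1ccc(C(F)(F)F)cc1N1CCC(Cc2ccccc2)CC1)c1ccc(NS(C)(=O)=O)c(F)c1` gives 1.4 nM in an assay on CHO cells for antagonist activity at transient receptor potential cation channel subfamily V member 1 (Homo sapiens), read by FLIPR; a lower number here means a stronger inhibitor, a higher number a weaker inhibitor. Compound 2 `Cc1cccc(N2CCN(c3cc(C(F)(F)F)ccc3CNC(=O)C(C)c3ccc(NS(C)(=O)=O)c(F)c3)CC2)c1` gives 1.8 nM in this assay. Compound 3 `CC(C(=O)NCc1ccc(C(F)(F)F)cc1OC1CCCCC1)c1ccc(NS(C)(=O)=O)c(F)c1` gives 0.7 nM in this assay, the lowest of the three numbers; its gap to compound 1 lies within the scatter, while its gap to compound 2 lies beyond it.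

Compound 4 `CC(C(=O)NCc1ccc(C(F)(F)F)cc1-c1cccnc1)c1ccc(NS(C)(=O)=O)c(F)c1` is not yet measured. Relative to compound 3 the change is pyridin-3-yl in place of cyclohexyloxy on an aromatic carbon. For the measured compounds named here, no pair of measured compounds shows this kind of exchange, so no step of known size is available to guide the expectation.

The expected step from compound 3 to compound 4 is a 5.7-fold higher number from compound 3 to compound 4 (0.76 log units; beyond the scatter), a moderate loss beyond the scatter, since the three measured compounds all carry a large non-aromatic or saturated-ring-bearing group at this carbon and the pyridin-3-yl is a smaller aromatic ring. Compound 4 is therefore estimated at 4 nM in this assay, with a range from 1 nM to 16 nM.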

Compound 4, inhibition constant: 59.4 nM
Compound 4: middle estimate off by 15-fold (1.17 log units), on the low side, outside the stated range (above it).
By their numbers in this assay, from the lowest: compounds 3, 1 and 2 (each within the scatter of the next, the first and the last beyond it); then compound 4.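

This position is not indifferent to the group it carries: in this assay the exchange gives an 85-fold higher number from compound 3 to compound 4 (1.93 log units; beyond the scatter), a large loss set against the narrower spread of the earlier groups, from compound 3 at 0.7 nM to compound 2 at 1.8 nM. The exchange keeps a single six-membered ring and leaves the hydrogen-bond donor and acceptor counts unchanged, so those features alone do not preserve the low number at this aromatic carbon. Nothing available accounts for the size of this step.

The compounds shown leave open whether the loss follows the ring nitrogen, the aromatic ring or the missing oxygen link. Phenyl, phenoxy and cyclohexyl groups at this carbon would separate these three changes.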